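A few compounds are considered here, and "the series" means these few. Any claim that something is new, unique, unknown or untested is made for them only; others in the source may bear on it.

The study concerns a small set of aryl ethers built on an aminoquinoline-type core and tested in an assay on cells with melanin-concentrating hormone receptor 1 (Homo sapiens) as the target, read by radioligand binding; a higher number here means a weaker inhibitor, a lower number a stronger inhibitor. Compound 2, `CC1CCC(Oc2cccc3ccc(N)nc23)C1`, carries a 3-methylcyclopentyl group on the ring oxygen, and in this assay compound 2 gives 823 nM. Going by the values given here, it is the only compound in the set for which a number is reported at all. Compound 1, `COCCOCCOc1cccc2ccc(N)nc12`, returns only a limit of the assay: in this assay compound 1 gives > 2000 nM. Compound 3, `CC(CC(C)(C)C)Oc1cccc2cccnc12`, which lacks the amino group on the core, likewise returns only a limit: in this assay compound 3 gives > 2000 nM. Compound 2 therefore stands alone as a measured value, with the other two results sitting at the limit of > 2000 nM in this assay, at which 2 of the 3 values shown sit.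

The next compound, compound 4, `CC#CCCOc1cccc2ccc(N)nc12`, keeps the aminoquinoline core and the ring oxygen but changes the group on it: pent-3-yn-1-yl in place of 3-methylcyclopentyl on an oxygen on an aromatic ring. Among the compounds with values here, no measured pair in the set differs by a change of this kind, so no directly comparable step exists. A modest weakening is expected, since the chain that enters is smaller than the ring that leaves, though the change could equally fall within the scatter. The step from compound 2 to compound 4 in this assay is expected to be a 1.8-fold higher number from compound 2 to compound 4 (0.26 log units; within the scatter). Compound 4 is estimated at 1500 nM, with a likely range from 500 nM to 5000 nM.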

Compound 4, half-maximal inhibitory concentration: > 2000 nM
Compound 4: only a limit was reported (the forecaster's own chance of this, stated with the estimate: 35%); middle value at least 1.3-fold (0.12 log units) away from the limit.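

In this assay, going by these compounds alone, this is the first readable comparison at the group on an oxygen on an aromatic ring, and it shows that this position is sensitive to the change: pent-3-yn-1-yl in place of 3-methylcyclopentyl gives an at least 2.4-fold higher number from compound 2 to compound 4 (0.38 log units; beyond the scatter). Compound 4 returns only a limit of the assay, so this step sets a minimum and not a size, and the step from compound 1 to compound 4 cannot be read, as both ends are limits. Compound 2 is still the only compound with a number, and its 3-methylcyclopentyl group is the only group on this oxygen shown to give one, while the rest of the set reads as follows: the limit of > 2000 nM in this assay, at which 3 of the 4 values shown sit.

The compounds shown leave open whether the higher number goes with the loss of the ring or with the arrival of the triple bond, as both change in this one step. A plain pentyl chain on the same oxygen would separate those two changes, and an unsubstituted cyclopentyl or a cyclohexyl would show how much of the value of compound 2 rests on the methyl group or on the ring size.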